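Methoxy for Bromo on the Anilino Ring of Compound 2

The compounds below may be only part of what the source reports. "The series", "measured", "known", "first", "only" and "open" are said of these compounds alone.

Compound 2 `C=CC(=O)Nc1cccc(NC(=O)CSc2nc(Nc3cccc(Br)c3)c3ccccc3n2)c1` gives 19400 nM in a functional assay on MDA-MB-231 cells (Homo sapiens) for inhibition, read by MTT assay, with a stated time of 72 h; on this read-out lower numbers stand for stronger inhibition and higher numbers for weaker inhibition. Going by the values given here, compound 1 `C=CC(=O)Nc1cccc(NC(=O)CSc2nc(Nc3ccccc3F)c3ccccc3n2)c1` gives 18700 nM in this assay, and the step of a 1.0-fold higher number from compound 1 to compound 2 (0.02 log units; within the scatter) leaves compound 2 level with compound 1, the only other measured compound, neither standing apart from the other beyond the scatter. Compound 3 `C=CC(=O)Nc1cccc(NC(=O)CSc2nc(Nc3cccc(OC)c3)c3ccccc3n2)c1` has not yet been measured. It differs from compound 2 in one place: methoxy in place of bromo on an aromatic carbon. Among the compounds with values here, the only measured step that bears on this change is the earlier exchange of the aryl group on the same nitrogen, a 1.0-fold higher number from compound 1 to compound 2 (0.02 log units; within the scatter), which shows nothing beyond the scatter; the data hold no example of a methoxy group at this position. On that basis compound 3 is expected to show a step of a 1.0-fold lower number from compound 2 to compound 3 (0.01 log units; within the scatter), that is, no change beyond the scatter. The estimate for compound 3 in this assay is therefore 19000 nM, with a range from 9000 nM to 40000 nM.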

Compound 3, half-maximal inhibitory concentration: 12900 nM
For compound 3 the middle estimate is 1.5-fold (0.17 log units) above the measured one; low and high end bracket the measured number.
By their numbers in this assay, from the lowest: compounds 3, 1 and 2 (each within the scatter of the next).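

Methoxy in place of bromo on this aromatic carbon gives a step in this assay that stays within the scatter (a 1.5-fold lower number from compound 2 to compound 3 (0.18 log units; within the scatter)), and the exchange of the whole aryl group on the nitrogen does the same (a 1.4-fold lower number from compound 1 to compound 3 (0.16 log units; within the scatter)). With compound 3, a group carrying a hydrogen-bond acceptor joins the series, and the 2-fluorophenyl, 3-bromophenyl and 3-methoxyphenyl compounds all stand within the scatter of one another. Nothing measured here speaks to a cause for these numbers.

The compounds shown leave open whether any group at this place can move the number beyond the scatter. An amine or a carboxylic acid on the same aromatic carbon, or a longer chain such as ethoxy in place of methoxy, would put that to the test.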